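Dropping a Chloro Group from the Strongest of Three

A few compounds are considered here, and "the series" means these few. Any claim that something is new, unique, unknown or untested is made for them only; others in the source may bear on it.

Of the compounds shown here, three have been tested in a functional assay on LOX IMVI cells (Homo sapiens) for cytotoxicity, read by sulforhodamine B assay, with a stated time of 48 h; on this read-out higher numbers stand for weaker inhibition of growth and lower numbers for stronger inhibition of growth. Compound 1 `ClCc1ccc(Cn2cnc3c(Cl)ncnc32)cc1` gives 3460 nM, compound 2 `ClCc1cccc(Cn2cnc3nc(Cl)nc(Cl)c32)c1` gives 790 nM, and compound 3 `ClCc1ccccc1Cn1cnc2nc(Cl)nc(Cl)c21` gives 350 nM, the lowest number of the three and beyond the scatter from both others, so compound 3 is the strongest growth inhibitor so far. The next compound, compound 4 `ClCc1ccccc1Cn1cnc2ncnc(Cl)c21`, differs from compound 3 in one place: hydrogen in place of chloro on an aromatic carbon. Going by the values given here, no measured pair shows this change by itself, so its effect is unknown. Compound 1, whose core also carries a single chloro group, gives the weakest number, but its other differences cloud the comparison. A moderate weakening is expected for the step of a 2.9-fold higher number from compound 3 to compound 4 (0.46 log units; beyond the scatter). Compound 4 is therefore estimated at 1000 nM, with a likely range from 350 nM to 3000 nM.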

Compound 4, concentration for total growth inhibition: 3090 nM
The estimate for compound 4 lay 3.1-fold (0.49 log units) below the measured number; the measured number lies above the stated range.
By their numbers in this assay, from the lowest: compound 3; then compound 2; then compounds 4 and 1 (each within the scatter of the next).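

In this assay, putting hydrogen in place of chloro on the aromatic carbon between two ring nitrogen atoms gives an 8.8-fold higher number from compound 3 to compound 4 (0.95 log units; beyond the scatter) and nothing else in the structure changes. Going by these compounds alone, this is the first direct view of that swap, and it shows that growth inhibition here depends strongly on this chloro group. The other chloro group on the core remains in compound 4, so the loss belongs to this one position.

As far as these compounds go, whether an amine, a methoxy group or a fluoro group at this carbon would keep the strength of compound 3 stays open. Nothing available explains why removing this chloro group weakens growth inhibition.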